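Swapping Methoxy for Cyano: What to Expect

This account rests on a few compounds, and the source may have more. Where it says the series, first, only, none or still open, it means among the compounds named here.

In a functional assay on DU-145 cells (Homo sapiens) for antiproliferative activity, read by sulforhodamine B assay, with a stated time of 48 h (on this read-out higher numbers stand for weaker inhibition of growth and lower numbers for stronger inhibition of growth), compound 1 `COc1ccc(Nc2nc(NC3CCCC3)c3ccccc3n2)cc1` gives 12400 nM. Going by the values given here, its only measured neighbour, compound 2 `COc1ccc(Nc2nc(NCCCO)c3ccccc3n2)cc1`, gives 18300 nM, so the two cannot be told apart on these numbers.

Compound 3 `N#Cc1ccc(Nc2nc(NC3CCCC3)c3ccccc3n2)cc1` has not yet been measured. It keeps the cyclopentyl group and the shared core of compound 1 but alters a different place: cyano in place of methoxy on an aromatic carbon. Put simply, the 4-methoxyphenyl of compound 1 becomes 4-cyanophenyl in compound 3.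

Among the compounds with values here, the only measured step is a 1.5-fold higher number from compound 1 to compound 2 (0.17 log units; within the scatter). It puts 3-hydroxypropyl in place of cyclopentyl on a nitrogen, so it says nothing direct about the methoxy position. Within the data shown here, with no measured step at that position, there is no basis for predicting a direction, and no step beyond the scatter is expected in this assay. The range must stay wide for the same reason. The expected step is a 1.1-fold higher number from compound 1 to compound 3 (0.05 log units; within the scatter). The estimate for compound 3 is 14000 nM, with an expected range from 5000 nM to 40000 nM.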

Compound 3, concentration for 50% growth inhibition: > 31300 nM
Compound 3 ended at the assay's limit; the forecaster's own chance of this, stated with the estimate: 12%; middle value at least 2.2-fold (0.34 log units) from the limit.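

Cyano in place of methoxy on an aromatic carbon gives an at least 2.5-fold higher number from compound 1 to compound 3 (0.40 log units; beyond the scatter) in this assay, so growth inhibition is weaker, even though the group that leaves and the group that enters each count 2 heavy atoms and 1 hydrogen-bond acceptor. Going by these compounds alone, this is the first step here to lie beyond the scatter, and it shows that the place para to a large group can change the read-out, which a 1.5-fold higher number from compound 1 to compound 2 (0.17 log units; within the scatter), made at a nitrogen, could not show. How much weaker compound 3 really is cannot be read, because its value is a limit and not a number: the limit of > 31300 nM in this assay, at which 1 of the 3 values shown sits.

With only methoxy and cyano shown at this place, it remains open whether the weaker result comes from losing methoxy or from bringing in cyano, and an amine, an ethoxy group or a plain hydrogen there would help to separate the two. Going by these compounds, it is also open whether the same swap would have a similar effect with 3-hydroxypropyl on the nitrogen, as in compound 2.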